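Adding a Cyclohexenyl Cap to a Bare Alkyne

This account rests on a few compounds, and the source may have more. Where it says the series, first, only, none or still open, it means among the compounds named here.

Measured in a functional assay on 1321-N1 cells for agonist activity at Free fatty acid receptor 1 (Homo sapiens), read by calcium flux, with a stated time of 0.4 s; a higher number here means that more compound is needed for the effect, a lower number that less compound is needed:
- compound 1 `C#Cc1ccc(CCC(=O)O)cc1`: > 100000 nM
- compound 2 `C/C=C(/C)C#Cc1ccc(CCC(=O)O)c(F)c1`: 20.4 nM; 20 nM (2 entries)
- compound 3 `O=C(O)CCc1ccc(C#CC2(O)CCCCC2)cc1`: < 100000 nM

Compound 1 stands at the top edge of what this assay can report: its value is a limit of the assay, not a number, so it shows no measurable effect at the concentrations tested. Compound 2 gives a clear number, supported by the several entries of compound 2 in this assay, 20.4 nM; 20 nM (2 entries). Compound 3 also sits at a limit of the assay rather than at a number, so its activity is bounded only on one side.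

Compound 4 `O=C(O)CCc1ccc(C#CC2=CCCCC2)cc1` is compound 1 with one change: cyclohex-1-en-1-yl in place of hydrogen on a triple-bonded carbon. Within the data shown here, no pair of measured compounds isolates this exact change, so its size has to be expected rather than read off. The direction looks plausible from compound 2, which also carries a carbon group on the triple-bonded carbon and gives 20.4 nM; 20 nM (2 entries), though compound 2 additionally carries a fluorine on the ring.

Compound 4 is expected to need far less compound than compound 1, an estimated step of an at least 330-fold lower number from compound 1 to compound 4 (2.52 log units; beyond the scatter) in this assay. Compound 4 is therefore estimated at 300 nM, with a range from 30 nM to 5000 nM.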

Compound 4, half-maximal effective concentration: 200 nM
Estimate against measurement, compound 4: 1.5-fold (0.18 log units) above; the measured number falls inside the stated range.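

In this assay, cyclohex-1-en-1-yl in place of hydrogen on a triple-bonded carbon gives an at least 500-fold lower number from compound 1 to compound 4 (2.69 log units; beyond the scatter), the only step shown that isolates a single change at this carbon. Compound 1 stands at > 100000 nM, which is a limit of the assay. Among these compounds, the step shows that a ring of carbon only, placed on this otherwise bare triple-bonded carbon, is enough to turn the core of compound 1 into a compound with a measured number in this assay, something the earlier compounds could only hint at, as compound 2 also differs in its fluorine.

Compound 3, which carries a hydroxyl group on a six-membered ring at the same carbon, stands at < 100000 nM, which is also a limit of the assay. Any step to compound 3 therefore cannot be read, and the compounds shown leave open whether the double bond of the ring matters, and whether a phenyl ring, a cyclopentenyl ring or a longer carbon chain in the same place would serve as well as cyclohex-1-en-1-yl.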